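Compound 1 to compound 3: a swap at the limit

This account rests on a few compounds, and the source may have more. Where it says the series, first, only, none or still open, it means among the compounds named here.

Compound 1 (`O=C(Nc1ccc(F)c(-c2nc3ccccc3o2)c1)c1cc([N+](=O)[O-])ccc1Cl`) is the starting point here, and its standing is simple to state. In an ADME assay on BJ cells (Homo sapiens) for cytotoxicity, with a stated time of 72 h (on this read-out lower numbers stand for an effect already at smaller amounts and higher numbers for an effect only at larger amounts of compound), compound 1 gives > 25000 nM, which is a limit of the assay and not a number. Its relative compound 2 (`Cc1cc(NC(=O)c2cc([N+](=O)[O-])ccc2Cl)cc(-c2nc3ccccc3o2)c1O`) gives > 25000 nM, which is also a limit. Going by the values given here, the whole record so far is therefore (the limit of > 25000 nM in this assay, at which 2 of the 2 values shown sit), and no measured step between compounds is available as a guide.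

Compound 3 (`O=C(Nc1ccc(F)c(-c2nc3ccccc3s2)c1)c1cc([N+](=O)[O-])ccc1Cl`) is not yet measured. It carries 1,3-benzothiazol-2-yl in place of 1,3-benzoxazol-2-yl on an aromatic carbon, ortho to a fluoro group: 1,3-benzothiazol-2-yl in place of 1,3-benzoxazol-2-yl on an aromatic carbon. The two groups match in everything counted except that one atom, sulfur for oxygen.

The expectation rests on the reading of > 25000 nM for compound 1, and no direction can be favoured from it. What is expected is a number no higher from compound 1 to compound 3 (the limit leaves the size open), a change no larger than the usual scatter. For compound 3 the estimate is 25000 nM, with an expected range from 10000 nM to 50000 nM, and another limit is the likeliest report.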

Compound 3, half-maximal effective concentration: > 25000 nM
Compound 3 was reported as a limit; the forecaster's own chance of this, stated with the estimate: 75%; the middle value sits exactly at the limit.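

Going by these compounds alone, compound 1 and compound 3 both sit at a limit of the assay, so putting 1,3-benzothiazol-2-yl in place of 1,3-benzoxazol-2-yl gives no step that can be read between them. The compounds shown leave open at what concentration any of them would harm these cells, and all share one reading: the limit of > 25000 nM in this assay, at which 3 of the 3 values shown sit.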